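The source may report more compounds than this note shows. Statements on the series, on what has been measured and on what is new or still open speak of the compounds shown alone.

In a functional assay on P388 cells (Mus musculus) for cytotoxicity (a lower number here means a stronger inhibitor, a higher number a weaker inhibitor), compound 3 `COc1ccc(C[C@H]2C(=O)N[C@@H](C)C(=O)N(C)[C@H]3Cc4ccc(cc4)Oc4cc(ccc4OC)C[C@@H](C(=O)N[C@H](C)C(=O)N[C@@H](CCCCO)C(=O)N2C)N(C)C3=O)cc1` gives 219 nM, the highest of the three numbers, with compound 1 `COC(=O)CC[C@@H]1NC(=O)[C@@H](C)NC(=O)[C@@H]2Cc3ccc(OC)c(c3)Oc3ccc(cc3)C[C@@H](C(=O)N2C)N(C)C(=O)[C@H](C)NC(=O)[C@H](Cc2ccc(OC)cc2)N(C)C1=O` at 58.9 nM and compound 2 `C=CC[C@@H]1NC(=O)[C@@H](C)NC(=O)[C@@H]2Cc3ccc(OC)c(c3)Oc3ccc(cc3)C[C@@H](C(=O)N2C)N(C)C(=O)[C@H](C)NC(=O)[C@H](Cc2ccc(OC)cc2)N(C)C1=O` at 38.9 nM. Compound 4 `CCC[C@@H]1NC(=O)[C@@H](C)NC(=O)[C@@H]2Cc3ccc(OC)c(c3)Oc3ccc(cc3)C[C@@H](C(=O)N2C)N(C)C(=O)[C@H](C)NC(=O)[C@H](Cc2ccc(OC)cc2)N(C)C1=O` differs from compound 3 thus: hydrogen in place of hydroxymethyl on a saturated chain carbon, three bonds along the chain from a saturated ring carbon, which also reads as 4-hydroxybutyl to propyl. Within the data shown here, two measured steps bear on this change, a 3.7-fold higher number from compound 1 to compound 3 (0.57 log units; beyond the scatter) and a 5.6-fold higher number from compound 2 to compound 3 (0.75 log units; beyond the scatter), and both lead to the chain carrying the hydroxymethyl. The remaining step, a 1.5-fold lower number from compound 1 to compound 2 (0.18 log units; within the scatter), lies within the scatter. On these steps, a modest fall of similar size is expected, a 4.4-fold lower number from compound 3 to compound 4 (0.64 log units; beyond the scatter). Compound 4 is estimated at 50 nM, with an expected range of 20 nM to 125 nM.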

Compound 4, half-maximal inhibitory concentration: 13.8 nM
Compound 4: middle estimate off by 3.6-fold (0.56 log units), on the high side, and the stated range ends above it.
By their numbers in this assay, from the lowest: compound 4; then compounds 2 and 1 (each within the scatter of the next); then compound 3.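

In this assay, removing the hydroxymethyl to turn 4-hydroxybutyl into propyl gives a 16-fold lower number from compound 3 to compound 4 (1.20 log units; beyond the scatter), the largest step seen at this position. Propyl also improves on the other chains, with a 2.8-fold lower number from compound 2 to compound 4 (0.45 log units; beyond the scatter) against the vinyl-bearing chain and a 4.3-fold lower number from compound 1 to compound 4 (0.63 log units; beyond the scatter) against the methoxycarbonyl-bearing chain, so none of these three groups matches the plain propyl chain here. Nothing available explains this ordering. The compounds shown leave open whether an ethyl or a butyl chain would give a lower number than propyl, and how an amine or a carboxylic acid in place of the hydroxymethyl would compare.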